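Benzylamide aryl substituents on the shared core

The source may report more compounds than this note shows. Statements on the series, on what has been measured and on what is new or still open speak of the compounds shown alone.

Measured so far in an assay on microsomes from liver for inhibition of 3-hydroxy-3-methylglutaryl-coenzyme A reductase (Rattus norvegicus), read by scintillation counting, with stated times of 0.5 h and 0.75 h; a higher number here means a weaker inhibitor, a lower number a stronger inhibitor:
compound 1 `O=C(O)C[C@H](O)C[C@H](O)CCn1c(-c2ccc(F)cc2)nc(C(=O)NCc2ccccc2F)c1C1CC1` gives 1.5 nM
compound 2 `O=C(O)C[C@H](O)C[C@H](O)CCn1c(-c2ccc(F)cc2)nc(C(=O)NCc2cccc(F)c2)c1C1CC1` gives 1.2 nM
compound 3 `COc1ccc(CNC(=O)c2nc(-c3ccc(F)cc3)n(CC[C@@H](O)C[C@@H](O)CC(=O)O)c2C2CC2)cc1` gives 1.2 nM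

Compound 3 stands level with compound 2 at the digits shown; together they carry the lowest two numbers of the three, and compound 1 is the furthest from compound 3, yet the three numbers lie within the scatter of each other, so no order can be claimed among them.

Compound 4 `CN(C)S(=O)(=O)c1ccc(CNC(=O)c2nc(-c3ccc(F)cc3)n(CC[C@@H](O)C[C@@H](O)CC(=O)O)c2C2CC2)cc1` differs from compound 3 by dimethylsulfamoyl in place of methoxy on an aromatic carbon. Going by the values given here, the steps that bear on this change are those that alter the substituent on the same phenyl ring: a 1.3-fold lower number from compound 1 to compound 2 (0.10 log units; within the scatter), a 1.3-fold lower number from compound 1 to compound 3 (0.10 log units; within the scatter) and no change at the digits printed from compound 2 to compound 3 (within the scatter). Each of them stays within the scatter. Among the compounds with values here, the change here is larger, the entering group carrying more heavy atoms and one more acceptor, but no measured step shows the ring substituent moving this assay, so compound 4 is expected to give 1.5 nM, within 0.6 nM to 4 nM. The expected step is a 1.3-fold higher number from compound 3 to compound 4 (0.10 log units; within the scatter), no change beyond the scatter.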

Compound 4, half-maximal inhibitory concentration: 4.9 nM
Beside the measured number, compound 4's estimate is 3.3-fold (0.51 log units) below it; the whole stated range lies below it.
By their numbers in this assay, from the lowest: compounds 2, 3 and 1 (each within the scatter of the next); then compound 4.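

The ring substituent on the benzylamide does move the number in this assay: the step is a 4.1-fold higher number from compound 3 to compound 4 (0.61 log units; beyond the scatter), and the other two comparisons read a 4.1-fold higher number from compound 2 to compound 4 (0.61 log units; beyond the scatter) and a 3.3-fold higher number from compound 1 to compound 4 (0.51 log units; beyond the scatter). Among the earlier compounds, 2-fluorophenyl, 3-fluorophenyl and 4-methoxyphenyl stayed within the scatter of each other, so 4-(dimethylsulfamoyl)phenyl is the only one of the four set apart, and in the direction of a weaker inhibitor. No evidence at hand accounts for this step.

Going by these compounds, it remains open whether the step belongs to the dimethylsulfamoyl group as a whole or to some part of it. Methylsulfonyl or nitrile on the same aromatic carbon would test how far the step extends beyond this one group.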